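Pyridin-4-yl for Pyridin-3-yl on an Amine Nitrogen

The compounds below may be only part of what the source reports. "The series", "measured", "known", "first", "only" and "open" are said of these compounds alone.

Two compounds have been measured in a functional assay on A-375 cells (Homo sapiens) for antiproliferative activity, read by CCK-8 assay, with a stated time of 72 h, tested at 2 uM; a lower number here means a weaker effect, a higher number a stronger effect of the compound at the concentration tested:

compound 1, `Nc1ccccc1NC(=O)c1ccc(CSC(=S)N2CCN(c3cccnc3)CC2)cc1` — 40.5%
compound 2, `CC1CCCCN1C(=S)SCc1ccc(C(=O)Nc2ccccc2N)cc1` — 42.5%

In this assay the numbers of compound 1 and compound 2 lie within the usual scatter of each other, so no order between the two can be claimed; they read as one level of activity.

Compound 3, `Nc1ccccc1NC(=O)c1ccc(CSC(=S)N2CCN(c3ccncc3)CC2)cc1`, has not yet been measured. Set against compound 1, the change is pyridin-4-yl in place of pyridin-3-yl on an amine nitrogen in a ring. Going by the values given here, no step between measured compounds that differ in a single place is available, so there is nothing to calibrate the size of this change against. The step of a number 1.5 percentage points higher from compound 1 to compound 3 (within the scatter) is expected to be none beyond the scatter, in neither direction, because compound 1 gives 40.5% and compound 2 gives 42.5% at essentially the same level despite a different group on the same amine nitrogen. Compound 3 is therefore estimated at 42%, with a range from 28% to 56%.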

Compound 3, a percentage reported as inhibition, at one concentration (the size of the read-out at that concentration, not a potency): 85.7%
For compound 3 the middle estimate is 43.7 percentage points below the measured one; measured number above the stated range.
By their numbers in this assay, from the lowest: compounds 1 and 2 (each within the scatter of the next); then compound 3.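

In this assay, going by these compounds alone, pyridin-4-yl in place of pyridin-3-yl on the amine nitrogen of the six-membered ring gives a number 45.2 percentage points higher from compound 1 to compound 3 (beyond the scatter), the first step that can be read at a single place, and it shows that this position is far from indifferent to the change. The leaving and entering groups have the same heavy atoms, the same ring and the same counts of hydrogen-bond donors and acceptors, so a rearrangement of the same atoms alone separates compound 3 from compound 1 by a large margin. Nothing available explains why the arrangement in pyridin-4-yl reads so much higher than the one in pyridin-3-yl.

The compounds shown leave open how pyridin-2-yl, or a plain phenyl ring, would read on the same nitrogen, which would show whether the step belongs specifically to pyridin-4-yl or whether pyridin-3-yl is the unusual case. Because the read-out comes from one concentration and is not a potency, the compounds also leave open how large the separation between compound 1 and compound 3 would be across a range of concentrations.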